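Serum half-life in the phosphate series: removing the benzoyl

This account rests on a few compounds, and the source may have more. Where it says the series, first, only, none or still open, it means among the compounds named here.

Compound 1 `O=C(O[C@H]1C[C@H](n2cc(F)c(=O)[nH]c2=O)O[C@@H]1COP(=O)(O)Oc1ccccc1)c1ccccc1` is the reference point of the series. In an ADME assay on a cell-free system (serum, Homo sapiens) for metabolic stability, read by HPLC, tested at 2 mM (on this read-out higher numbers stand for a longer-lived compound and lower numbers for a shorter-lived compound), compound 1 gives 5.1 h, the lowest of the two numbers shown. Compound 3 `O=C(O[C@H]1C[C@H](n2cc(F)c(=O)[nH]c2=O)O[C@@H]1COP(=O)(O)Oc1cccnc1)c1ccccc1` gives 17.8 h, a step of a 3.5-fold higher number from compound 1 to compound 3 (0.54 log units; beyond the scatter). Compound 2 `CCCCCCCCCc1ccc(OP(=O)(O)OC[C@H]2O[C@@H](n3cc(F)c(=O)[nH]c3=O)C[C@@H]2OC(=O)c2ccccc2)cc1` gives > 120 h, which is a limit of the assay rather than a number. The step of an at least 23-fold higher number from compound 1 to compound 2 (1.37 log units; beyond the scatter) ends at the limit of > 120 h in this assay, at which 1 of the 3 values shown sits. Compound 4 `O=c1[nH]c(=O)n([C@H]2C[C@H](O)[C@@H](COP(=O)(O)Oc3ccccc3)O2)cc1F` differs from compound 1 by hydrogen in place of benzoyl on an oxygen on a saturated carbon. Within the data shown here, both measured steps alter the aryl side of the phosphate and leave the benzoyl untouched, so neither bears directly on this change, and no measured step sets its size; only a modest move is expected. Compound 4 is expected to give 3.5 h, between 1.2 h and 10 h, a step of a 1.5-fold lower number from compound 1 to compound 4 (0.16 log units; within the scatter).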

Compound 4, half-life: 52.3 h
Compound 4: middle estimate off by 15-fold (1.17 log units), on the low side; the whole stated range lies below it.
By their numbers in this assay, from the lowest: compound 1; then compound 3; then compound 4. At a limit, above all of these: compound 2.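

Benzoyloxy to hydroxy on the core of compound 1 is a large change in this assay, with a 10-fold higher number from compound 1 to compound 4 (1.01 log units; beyond the scatter), so the half-life also responds to a change outside the aryl side of the phosphate, which the earlier steps did not show. Dropping the benzoyl lengthens the half-life here rather than shortening it. Nothing measured in this series accounts for that rise.

From the compounds shown here alone, whether the rise holds with the nonyl or pyridin-3-yl aryl groups stays open. Also open, going by these compounds, is whether an acetyl group on that oxygen behaves like benzoyl or like hydrogen.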